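Replacing a Methoxyphenyl Imine in a Thiosemicarbazone Series

This account rests on a few compounds, and the source may have more. Where it says the series, first, only, none or still open, it means among the compounds named here.

Compound 1 `COc1ccc(/C=N\NC(=S)NC(C)(C)CCC[C@](C)(O)[C@@H]2CC=C(C)CC2)cc1` was tested in a functional assay on HT-29 cells (Homo sapiens) for cytotoxicity, read by sulforhodamine B assay; a higher number here means that more compound is tolerated, a lower number that less compound is tolerated. Compound 1 gives > 100000 nM, which is a limit of the assay rather than a number. Compound 2 `CC1=CC[C@@H]([C@@](C)(O)CCCC(C)(C)NC(=S)N/N=C\c2ccccc2[N+](=O)[O-])CC1` gives 44400 nM. Compound 3 `CC1=CC[C@@H]([C@@](C)(O)CCCC(C)(C)NC(=S)N/N=C\c2cccc([N+](=O)[O-])c2)CC1` gives > 100000 nM, again only a limit. The measured steps are an at least 2.2-fold lower number from compound 1 to compound 2 (0.35 log units; beyond the scatter), a step that the two limits leave unreadable from compound 1 to compound 3 and an at least 2.2-fold higher number from compound 2 to compound 3 (0.35 log units; beyond the scatter). Two of the three values sit at the limit of > 100000 nM in this assay, at which 2 of the 3 values shown sit.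

Compound 4 `CC1=CC[C@@H]([C@@](C)(O)CCCC(C)(C)NC(=S)N/N=C(/C)c2ccccc2)CC1` carries a group of 9 heavy atoms (8 carbon, 1 nitrogen; one six-membered aromatic ring of carbon only) in place of a group of 10 heavy atoms (8 carbon, 1 nitrogen, 1 oxygen; one six-membered aromatic ring of carbon only), on an amide-type nitrogen. Only the change to 2-nitrophenyl produced a step beyond the scatter, and that one moved downward; the change to 3-nitrophenyl left the number at the limit. For compound 4 the expected step is a number no higher from compound 1 to compound 4 (the limit leaves the size open), probably none beyond the scatter. Compound 4 is therefore estimated at 100000 nM, with a range from 30000 nM to 300000 nM.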

Compound 4, concentration lethal to 50% of the cells: > 100000 nM
Compound 4: no number, only a limit (the forecaster's own chance of this, stated with the estimate: 60%); the middle value sits exactly at the limit.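

Among the compounds shown here, compound 4 gives > 100000 nM, which is only a limit of the assay, and compound 1 also stands at a limit, so no step between them can be read. The compounds shown leave open how far either true value lies past that limit, and so whether this change of group matters at all in this assay.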